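Series notes: aryl swap from compound 1 to compound 4

The source may report more compounds than this note shows. Statements on the series, on what has been measured and on what is new or still open speak of the compounds shown alone.

Measured so far, three compounds sharing one core:
compound 1 `CCOC(=O)C1=C(Nc2ccccc2)S/C(=C\c2ccc(Br)c(O)c2)C1=O` – 39.8%
compound 2 `CCOC(=O)C1=C(Nc2ccccc2)S/C(=C\c2ccccc2C(F)(F)F)C1=O` – 29%
compound 3 `CCOC(=O)C1=C(Nc2ccccc2)S/C(=C\c2cc(OC)c(O)c(OC)c2)C1=O` – 57.5%

All three numbers come from a functional assay on JAR cells (Homo sapiens) for inhibition, read by MTT assay, with a stated time of 72 h, tested at 10 uM; on this read-out higher numbers stand for more inhibition at the one concentration tested (going by the name of the read-out) and lower numbers for less inhibition. Compound 1 stands second highest of the three. Compound 2 lies lower than compound 1, and that gap is beyond the scatter; compound 3 lies higher than compound 1, also beyond the scatter. No two of the measured compounds differ in only one place, so no single step can be read off and nothing is known about how large a change at the exocyclic double bond moves the read-out.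

Compound 4 `CCOC(=O)C1=C(Nc2ccccc2)S/C(=C\c2cc3cccnc3[nH]2)C1=O` differs from compound 1 as follows: a group of 9 heavy atoms (7 carbon, 2 nitrogen; one five-membered aromatic ring with 1 hetero atom, one six-membered aromatic ring with 1 hetero atom) in place of a group of 8 heavy atoms (6 carbon, 1 oxygen, 1 bromine; one six-membered aromatic ring of carbon only), on a double-bonded chain carbon bound to a double-bonded ring carbon. Among the measured compounds shown here, with no measured step of this kind to lean on, the step of a number 0.2 percentage points higher from compound 1 to compound 4 (within the scatter) is expected to stay within the scatter, neither clearly up nor down. Compound 4 is therefore estimated at 40%, with a range from 20% to 60%.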

Compound 4, a percentage reported as inhibition, at one concentration (the size of the read-out at that concentration, not a potency): 54.3%
Compound 4: middle estimate off by 14.3 percentage points, on the low side; the measured number falls inside the stated range.
By their numbers in this assay, from the lowest: compound 2; then compound 1; then compounds 4 and 3 (each within the scatter of the next).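

In this assay, the exchange of 4-bromo-3-hydroxyphenyl for the group with one five-membered and one six-membered aromatic ring, each with 1 hetero atom, gives a number 14.5 percentage points higher from compound 1 to compound 4 (beyond the scatter). Among the compounds shown here, this is the first single-place step, and it shows that the group on the double-bonded chain carbon can move the read-out with the rest of the molecule unchanged, even though the counts of hydrogen-bond donors and acceptors and the net charge stay the same. The data on hand offer no explanation for this step.

From the compounds shown here alone, it remains open which part of the exchange carries the step: the departure of the bromine and hydroxyl or the entry of the ring nitrogens. An unsubstituted phenyl or an aminophenyl at this place would help separate these contributions.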